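A few compounds are considered here, and "the series" means these few. Any claim that something is new, unique, unknown or untested is made for them only; others in the source may bear on it.

Series notes, cytotoxicity on the shared core. Compound 1 `COc1cccc(/C=C2\CCC/C(=C\c3ccccc3Br)C2=O)c1OC` gives 10800 nM in a functional assay on HT-1080 cells (Homo sapiens) for cytotoxicity, read by MTT assay, with a stated time of 72 h; on this read-out lower numbers stand for stronger inhibition and higher numbers for weaker inhibition. Compound 2 `COc1cccc(/C=C2\CCC/C(=C\c3ccc(Br)cc3)C2=O)c1OC` gives 13700 nM in this assay. Among the compounds with values here, the only step between measured compounds, a 1.3-fold higher number from compound 1 to compound 2 (0.10 log units; within the scatter), concerns the bromophenyl group on the double-bonded chain carbon bound to a double-bonded ring carbon and stays within the scatter. On the two numbers in hand compound 2 holds the highest one, with compound 1 nearest; the two values are indistinguishable within the scatter, so no order between them is claimed.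

Compound 3 `COc1cccc(/C=C2\CCC/C(=C\c3ccc(Cl)c(Cl)c3)C2=O)c1OC` is not yet measured in this assay. Relative to compound 2 the change is 3,4-dichlorophenyl in place of 4-bromophenyl on a double-bonded chain carbon bound to a double-bonded ring carbon. Within the data shown here, the one measured step bearing on this position, a 1.3-fold higher number from compound 1 to compound 2 (0.10 log units; within the scatter), was within the scatter, and no measured compound carries a dichlorophenyl group, so there is no basis for expecting a step beyond the scatter in either direction. For compound 3 the expected step is therefore a 1.1-fold lower number from compound 2 to compound 3 (0.06 log units; within the scatter), kept small. Compound 3 is estimated at 12000 nM in this assay, with a range from 5000 nM to 30000 nM.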

Compound 3, half-maximal inhibitory concentration: 10800 nM
Beside the measured number, compound 3's estimate is 1.1-fold (0.05 log units) above it, and the stated range covers the measured number.
By their numbers in this assay, from the lowest: compounds 1, 3 and 2 (each within the scatter of the next).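

In this assay the two new steps, a 1.3-fold lower number from compound 2 to compound 3 (0.10 log units; within the scatter) and no change at the digits printed from compound 1 to compound 3 (within the scatter), both stay within the scatter. The earlier pair compared only two placements of a single bromine, whereas these steps show that 3,4-dichlorophenyl, with 8 heavy atoms and two chlorine atoms, can enter on a double-bonded chain carbon bound to a double-bonded ring carbon without its number separating from either bromophenyl compound. Across this small set, the change of halogen, halogen count and substitution pattern gives no order among the compounds, and nothing at hand offers an explanation for this flat picture.

All three groups are halogen-bearing phenyl rings, so the compounds shown leave open whether an amine, a carboxylic acid or a hydroxyl group on that ring would give a step beyond the scatter. They also leave open whether a pyridine ring in place of the phenyl ring, or a longer chain at this position, would separate from these three compounds in this read-out.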